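The source may report more compounds than this note shows. Statements on the series, on what has been measured and on what is new or still open speak of the compounds shown alone.

Of the compounds shown here, two have been measured in a functional assay on B16 cells (Mus musculus) for cytotoxicity, read by MTT assay, with a stated time of 72 h; a higher number here means a weaker inhibitor, a lower number a stronger inhibitor. Compound 1 `COc1cccc(/C=C/C(=O)Nc2cc(OC)c(OC)c(OC)c2)c1` gives 8500 nM. Compound 2 `COc1ccc(C(=O)c2cc(OC)c(OC)c(OC)c2)cc1NC(=O)/C=C/c1cc(OC)c(OC)c(OC)c1` gives 1200 nM, the lowest of the two numbers; compound 1 is the nearest, and the gap between the two lies beyond the usual scatter of such measurements. Compound 3 `COc1ccc(C(=O)c2cc(OC)c(OC)c(OC)c2)cc1NC(=O)/C=C/c1ccc(OC)c(OC)c1` is not yet measured. It differs from compound 2 in one place: hydrogen in place of methoxy on an aromatic carbon, which reads, one bond further out, as 3,4,5-trimethoxyphenyl becoming 3,4-dimethoxyphenyl on the cinnamamide side. Nothing in the measured pair shows what this particular change does, since compound 1 and compound 2 differ in more than one place. The step from compound 2 to compound 3 is therefore expected to be modest and, if anything, toward a higher number, with a 2.1-fold higher number from compound 2 to compound 3 (0.32 log units; beyond the scatter) as the estimated size. Compound 3 is expected to give about 2500 nM in this assay, within a range from 800 nM to 8000 nM.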

Compound 3, half-maximal inhibitory concentration: 6300 nM
For compound 3 the middle estimate is 2.5-fold (0.40 log units) below the measured one, and the stated range covers the measured number.
By their numbers in this assay, from the lowest: compound 2; then compounds 3 and 1 (each within the scatter of the next).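

In this assay, for the compounds shown here, replacing this methoxy with hydrogen, which turns 3,4,5-trimethoxyphenyl into 3,4-dimethoxyphenyl, gives a 5.3-fold higher number from compound 2 to compound 3 (0.72 log units; beyond the scatter) and is the first change that can be read in a single place. With the rest of the molecule held the same, this methoxy therefore counts, as its loss goes with a weaker inhibitor, something the earlier pair, differing in more than one place, could not show. Nothing measured on these compounds explains why this step goes the way it does.

The compounds shown leave open whether another group at this place, such as a hydroxy, a fluorine or an ethoxy, would keep the number of compound 2 or lose ground as hydrogen does. Going by these compounds alone, they also leave open whether the two remaining methoxy groups on this ring matter to the same degree, and whether the same change would act alike on the other 3,4,5-trimethoxyphenyl group, the one that compound 2 and compound 3 both carry at the carbonyl.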